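This account rests on a few compounds, and the source may have more. Where it says the series, first, only, none or still open, it means among the compounds named here.

Measured compounds in a functional assay on A2780 cells (Homo sapiens) for antiproliferative activity, read by fluorescence, with a stated time of 72 h; a higher number here means a weaker inhibitor, a lower number a stronger inhibitor:
- compound 1, `CN1CCC(C(=O)N2Cc3c(NC(=O)c4ccco4)n[nH]c3C2(C)C)CC1`, for which compound 1 gives > 5000 nM, a limit of the assay rather than a number.
- compound 2, `CC(=O)N1CCN(C(=O)N2Cc3c(NC(=O)c4ccc(F)cc4)n[nH]c3C2(C)C)CC1`, for which compound 2 gives > 10000 nM, again a limit rather than a number.

Compound 1 therefore stands at a limit only; of the two values shown, one sits at the limit of > 5000 nM in this assay, at which 1 of the 2 values shown sits, and the other at the limit of > 10000 nM in this assay, at which 1 of the 2 values shown sits. Among the measured compounds shown here, neither compound has a number, so no step between measured compounds can be counted, and nothing is known about how far below the limits either compound might lie.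

Compound 3, `CN1CCC(C(=O)N2Cc3c(NC(=O)c4ccc(F)c(F)c4)n[nH]c3C2(C)C)CC1`, has not yet been measured. It differs from compound 1 in one place: 3,4-difluorophenyl in place of furan-2-yl on a carbonyl carbon. Compound 2, which also carries a fluorine-bearing phenyl on its amide carbonyl, likewise gave only a limit. With both measured compounds at limits, the step from compound 1 to compound 3 is expected to be none beyond the scatter, and compound 3 is expected to return a limit as well. Compound 3 is estimated at 8000 nM, with a range from 2000 nM to 30000 nM. That estimate means an expected step that the limit leaves unreadable from compound 1 to compound 3.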

Compound 3, half-maximal inhibitory concentration: 100 nM
Beside the measured number, compound 3's estimate is 80-fold (1.90 log units) above it; measured number outside the range, below it.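

In this assay, putting 3,4-difluorophenyl in place of furan-2-yl on a carbonyl carbon gives an at least 50-fold lower number from compound 1 to compound 3 (1.69 log units; beyond the scatter), so the group at this position can decide whether the shared core shows measurable antiproliferative activity. Among the compounds shown here, compound 3 is the only one of the three compounds with a number rather than a limit, and this is the first readable sign that the series can reach the nanomolar range in this assay. The size of the step is only a bound, not an exact figure, because it starts from the limit of compound 1: the limit of > 5000 nM in this assay, at which 1 of the 3 values shown sits.

The compounds shown do not separate the change of ring from the two fluorines, and a plain phenyl or a thiophen-2-yl on the same carbonyl would speak to that question. Compound 2 differs from compound 3 in more than one place, so it cannot show how far this change carries over to other groups on the far side of the core, and these values alone do not tell why the step arises.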